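The compounds below may be only part of what the source reports. "The series", "measured", "known", "first", "only" and "open" are said of these compounds alone.

Measured compounds in a functional assay on MCF7 cells (Homo sapiens) for antiproliferative activity, read by MTT assay, with a stated time of 48 h; on this read-out higher numbers stand for weaker inhibition and lower numbers for stronger inhibition:
Compound 1 `O=c1cc(-n2cc(CNc3ccccc3)nn2)c2cc(Br)ccc2o1` gives only a limit, > 50000 nM.
Compound 2 `O=c1cc(-n2cc(COc3cccnc3)nn2)c2cc(Br)ccc2o1` gives 39800 nM.
Compound 3 `O=c1cc(-n2cc(COc3ccccc3Br)nn2)c2cc(Br)ccc2o1` gives 28900 nM.

Compound 3 and compound 2 differ only in the aryl on the ether oxygen, and the step of a 1.4-fold lower number from compound 2 to compound 3 (0.14 log units; within the scatter) lies within the scatter, so the two are indistinguishable here. The value of compound 1 is a limit (the limit of > 50000 nM in this assay, at which 1 of the 3 values shown sits), so the steps of an at least 1.2-fold lower number from compound 1 to compound 2 (0.09 log units; that floor lies within the scatter) and an at least 1.7-fold lower number from compound 1 to compound 3 (0.23 log units; that floor lies within the scatter) are floors only, both within the scatter.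

Compound 4 `O=c1cc(-n2cc(COc3ccccc3O)nn2)c2cc(Br)ccc2o1` follows from compound 3 by hydroxy in place of bromo on an aromatic carbon. Within the data shown here, no measured step swaps a substituent on this ring; the only change on the aryl ether, from compound 2 to compound 3, moved the number within the scatter, and nothing here shows an effect of a hydroxy. Hence in this assay no step beyond the scatter is expected for compound 4, in either direction. The expected step of a 1.1-fold higher number from compound 3 to compound 4 (0.04 log units; within the scatter) is therefore estimated at about nil, and compound 4 is estimated at 32000 nM, within 10000 nM to 100000 nM.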

Compound 4, half-maximal inhibitory concentration: 24800 nM
For compound 4 the middle estimate is 1.3-fold (0.11 log units) above the measured one; the measured number falls inside the stated range.
By their numbers in this assay, from the lowest: compounds 4, 3 and 2 (each within the scatter of the next). At a limit, above all of these: compound 1.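

In this assay, among these compounds, the first substituent swap on the aryl ring of the ether gives a 1.2-fold lower number from compound 3 to compound 4 (0.07 log units; within the scatter), so bromo and hydroxy cannot be told apart at this place, ortho to a large group. Set against the pyridin-3-yl ether, the 2-hydroxyphenyl ether gives a 1.6-fold lower number from compound 2 to compound 4 (0.21 log units; within the scatter), so the aryl on the ether oxygen still shows no effect beyond the scatter. Against the anilino compound the step reads an at least 2.0-fold lower number from compound 1 to compound 4 (0.30 log units; that floor lies within the scatter), and as compound 1 is a limit, this is a floor only: the limit of > 50000 nM in this assay, at which 1 of the 4 values shown sits.

As far as these compounds go, it remains open whether any group at this place, such as an amine, a methoxy or a carboxylic acid, moves the number beyond the scatter. Also open, from the compounds shown here alone, is what a longer chain to the ether oxygen would do, or a change to the bromo on the shared core.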